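Notes on the halogenated phenyl series

This account rests on a few compounds, and the source may have more. Where it says the series, first, only, none or still open, it means among the compounds named here.

Compound 2 `CCCn1c(=O)[nH]c2nc(-c3ccc(S(=O)(=O)N4CCN(c5cccc(Br)c5)CC4)cc3)[nH]c2c1=O` carries a 3-bromophenyl on the amine nitrogen in a ring. In an assay on CHO cells for displacement of a labelled ligand from adenosine receptor A1 (Homo sapiens), read by scintillation counting, with a stated time of 90 min, in the presence of a further agent that is not named here (on this read-out higher numbers stand for weaker inhibition and lower numbers for stronger inhibition), compound 2 gives only a limit of the assay, > 1000 nM. Compound 1 `CCCn1c(=O)[nH]c2nc(-c3ccc(S(=O)(=O)N4CCN(c5ccccc5Br)CC4)cc3)[nH]c2c1=O`, which bears 2-bromophenyl at the same place, serves for comparison. In this assay compound 1 likewise returns only a limit, > 1000 nM. The one step shown, a step that the two limits leave unreadable from compound 1 to compound 2, cannot be sized since (the limit of > 1000 nM in this assay, at which 2 of the 2 values shown sit). Compound 3 `CCCn1c(=O)[nH]c2nc(-c3ccc(S(=O)(=O)N4CCN(c5ccccc5F)CC4)cc3)[nH]c2c1=O` has not yet been measured. It differs from compound 2 by 2-fluorophenyl in place of 3-bromophenyl on an amine nitrogen in a ring. Among the measured compounds shown here, no measured step covers this exchange; the step from compound 1 to compound 2 is the only one touching the same position, and it leaves nothing readable. With both halogenated phenyl analogues sitting at the limit, compound 3 is expected to remain in the same weak region, with a step that the limit leaves unreadable from compound 2 to compound 3 as the estimated step, in no direction beyond the scatter. For compound 3 the estimate in this assay is 3000 nM, in the range 800 nM to 20000 nM, with a considerable chance that only a limit is again reported.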

Compound 3, inhibition constant: > 1000 nM
Compound 3 ended at the assay's limit (the forecaster's own chance of this, stated with the estimate: 75%); the middle value lies beyond the limit too.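

In this assay, among the compounds shown here, no step among compound 1, compound 2 and compound 3 can be read, since each value is a limit of the assay and not a number: the limit of > 1000 nM in this assay, at which 3 of the 3 values shown sit. The compounds shown leave open how strongly any of these halogenated phenyl analogues inhibits, and whether exchanging the halogenated phenyl group changes this at all.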